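The source may hold more compounds than are shown below. What is called first, only, known or untested is meant among the compounds shown, and "the series" means these compounds.

The compounds measured so far, each in a functional assay on the whole organism for inhibition, with Rattus norvegicus as the target, read by paw edema, with stated times of 1 h and 4 h, at a dose of 0.03 mg/kg by the oral route; a higher number here means more inhibition at the dose given (going by the name of the read-out), a lower number less inhibition:

Compound 1 `CC1=NN(C(=O)c2cc3ccccc3oc2=O)C(=O)C1CNc1ccccn1` gives 31.1%
Compound 2 `CC1=NN(C(=O)c2cc3ccccc3oc2=O)C(=O)C1CNc1ccc(O)c(C(=O)O)c1` gives 30.9%
Compound 3 `CC1=NN(C(=O)c2cc3ccccc3oc2=O)C(=O)C1CNc1ccc(C(=O)O)cc1` gives 63.6%

Compound 3 stands highest of the three. Its margin over compound 1 (a number 32.5 percentage points higher from compound 1 to compound 3 (beyond the scatter)) and over compound 2 (a number 32.7 percentage points higher from compound 2 to compound 3 (beyond the scatter)) lies beyond the scatter in both cases, whereas compound 1 and compound 2 sit within the scatter of each other (a number 0.2 percentage points lower from compound 1 to compound 2 (within the scatter)).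

Compound 4 `CC1=NN(C(=O)c2cc3ccccc3oc2=O)C(=O)C1CNc1ccc(O)cc1` differs from compound 3 in one place: hydroxy in place of carboxy on an aromatic carbon. For the measured compounds named here, no measured step removes the carboxy group by itself, so the expectation rests on neighbouring comparisons. The step of a number 32.7 percentage points higher from compound 2 to compound 3 (beyond the scatter) comes nearest: it exchanges 3-carboxy-4-hydroxyphenyl for 4-carboxyphenyl, and compound 2, the one that carries a hydroxy group, stands far below compound 3. The step of a number 32.5 percentage points higher from compound 1 to compound 3 (beyond the scatter) shows the same picture from another side: both compounds that lack the 4-carboxyphenyl group stand low, and compound 4 will be a third compound without it.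

A large downward step is therefore expected for compound 4: a number 25.6 percentage points lower from compound 3 to compound 4 (beyond the scatter). Compound 4 is estimated at 38%, with an expected range from 22% to 55%.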

Compound 4, a percentage reported as inhibition, in the whole organism at one dose (the size of the read-out at that dose, not a potency): 35.6%
Compound 4: the middle estimate sits 2.4 percentage points above what was measured; the measured number falls inside the stated range.
By their numbers in this assay, from the lowest: compounds 2, 1 and 4 (each within the scatter of the next); then compound 3.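

In this assay, for the compounds shown here, this is the first direct exchange at the ring carbon para to a large group, and hydroxy in place of carboxy there gives a clear loss (a number 28 percentage points lower from compound 3 to compound 4 (beyond the scatter)). Yet a carboxy group alone does not secure a high number: removing it from the 3-carboxy-4-hydroxyphenyl group of compound 2 leaves the result level (a number 4.7 percentage points higher from compound 2 to compound 4 (within the scatter)), so among these compounds only the 4-carboxyphenyl group of compound 3 stands apart, while the 4-hydroxyphenyl group and the pyridin-2-yl group stand level (a number 4.5 percentage points higher from compound 1 to compound 4 (within the scatter)). The data shown offer no independent measurement that would explain this pattern.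

The compounds shown leave open whether the high number needs the carboxylic acid itself, since a methyl ester, a primary amide or a tetrazole at the same ring carbon would test that, and a plain phenyl group would show what the ring gives with no substituent at all. They also leave open how a 3-carboxyphenyl group without the hydroxy would compare, which would separate the place of the carboxy group from the presence of the hydroxy group in compound 2.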